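A few compounds are considered here, and "the series" means these few. Any claim that something is new, unique, unknown or untested is made for them only; others in the source may bear on it.

Working notes on a small set of aminobenzimidazole-type analogues with a pentyl chain, read in an assay on HEK293 cells for agonist activity at Toll-like receptor 8 (Homo sapiens), read by reporter gene assay; on this read-out higher numbers stand for an effect only at larger amounts of compound and lower numbers for an effect already at smaller amounts.

Compound 1 `CCCCC1(O)C(N)=Nc2ccccc21` carries a butyl chain and a hydroxyl on a saturated ring carbon; in this assay compound 1 is reported as "not active" (no number reported). Compound 2 `CCCCCn1c(N)nc2c(C)cccc21` bears a methyl on the aromatic carbon ortho to the fused ring and gives 1130 nM. Compound 3 `CCCCCn1c(N)nc2cc(C)ccc21` places the methyl on a different aromatic carbon and gives 4570 nM. Compound 2 stands lowest of the two numbers shown, with compound 3 at a higher number beyond the scatter; no step between these two is tabulated, so only the two values are noted.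

Compound 4 `CCCCCn1c(N)nc2c(N)cccc21` is the next member. Compared with compound 2, the change is amino in place of methyl on an aromatic carbon. Within the data shown here, no pair in the set isolates this exchange, so its size is unknown. The expectation for compound 4 is a modest move, possibly toward a higher number, with a step of a 1.8-fold higher number from compound 2 to compound 4 (0.25 log units; within the scatter) in this assay. Compound 4 is estimated at 2000 nM, within 500 nM to 8000 nM.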

Compound 4, half-maximal effective concentration: 6600 nM
For compound 4 the middle estimate is 3.3-fold (0.52 log units) below the measured one; the measured number falls inside the stated range.
By their numbers in this assay, from the lowest: compound 2; then compounds 3 and 4 (each within the scatter of the next).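

Among these compounds, at this aromatic carbon, ortho to a fused ring, amino in place of methyl gives a 5.8-fold higher number from compound 2 to compound 4 (0.77 log units; beyond the scatter) in this assay and is the first exchange that can be read at a single place. The position therefore does not tolerate every small group equally on this read-out, even though the exchange swaps one heavy atom for another and the entering amino brings a hydrogen-bond donor and acceptor that methyl lacks. No measurement at hand bears on what lies behind this step.

From the compounds shown here alone, how a fluorine, a hydroxyl or a methoxy on this same carbon would read remains open. Also open, going by these compounds, are whether the step carries over to the aromatic carbon holding the methyl of compound 3 and how a longer chain in place of the pentyl would read.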